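The source may report more compounds than this note shows. Statements on the series, on what has been measured and on what is new or still open speak of the compounds shown alone.

Of the compounds shown here, three sharing a sulfonamide core have been measured in a functional assay on U-87MG ATCC cells for inhibition, with U-87 MG (Homo sapiens) as the target, read by MTT assay, with a stated time of 72 h; on this read-out higher numbers stand for weaker inhibition of growth and lower numbers for stronger inhibition of growth. Compound 1 `CC(C)(C)c1ccc(CNCCCNS(=O)(=O)c2cc(C(F)(F)F)cc(C(F)(F)F)c2)cc1` gives 2300 nM. Compound 2 `O=S(=O)(NCCNCc1ccc(-c2ccccc2)cc1)c1cc(C(F)(F)F)cc(C(F)(F)F)c1` gives 1400 nM. Compound 3 `O=S(=O)(NCCCNCc1ccc(-c2ccccc2)cc1)c1cc(C(F)(F)F)cc(C(F)(F)F)c1` gives 2200 nM; how the cores of compound 2 and compound 3 differ is not broken down here. Going from compound 3 to compound 1, the change is tert-butyl in place of phenyl on an aromatic carbon, and it gave a 1.0-fold higher number from compound 3 to compound 1 (0.02 log units; within the scatter). The unmeasured compound 4 `CC(C)(C)c1ccc(CNCCNS(=O)(=O)c2cc(C(F)(F)F)cc(C(F)(F)F)c2)cc1` arises from compound 2 by the same change, (tert-butyl in place of phenyl on an aromatic carbon), at the same place. For compound 4 the expected step from its parent is a 1.1-fold higher number from compound 2 to compound 4 (0.03 log units; within the scatter). That expectation rests on the earlier step of a 1.0-fold higher number from compound 3 to compound 1 (0.02 log units; within the scatter), which is within the scatter, so little movement is anticipated. Compound 4 is therefore estimated at 1500 nM, most likely between 700 nM and 3200 nM in this assay.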

Compound 4, concentration for 50% growth inhibition: 13000 nM
Compound 4: middle estimate off by 8.7-fold (0.94 log units), on the low side, outside the stated range (above it).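

Placing tert-butyl where phenyl stood gave a 9.3-fold higher number from compound 2 to compound 4 (0.97 log units; beyond the scatter), which here means weaker inhibition of growth. The same change therefore does not carry over by the same amount from one core to the other: the same change on two cores in this assay, a 1.0-fold higher number (0.02 log units; within the scatter) from compound 3 to compound 1 and a 9.3-fold higher number (0.97 log units; beyond the scatter) from compound 2 to compound 4, 8.9-fold (0.95 log units) apart, beyond the scatter of two such steps. Within the data shown here, this rests on only two steps, so it shows that the effect depends on the core but does not show why, or what the change would do on any further core.

The compounds shown leave open how a cyclohexyl group or a carboxylic acid would behave in the same place on each core. They also leave open whether a longer chain in the core would follow compound 2 or compound 3 in its response to this change.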